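One Added Methoxy on a Compound at the Assay Limit

The compounds below may be only part of what the source reports. "The series", "measured", "known", "first", "only" and "open" are said of these compounds alone.

In a functional assay on the whole organism for inhibition, with Nicotiana tabacum as the target (on this read-out higher numbers stand for an effect only at larger amounts of compound and lower numbers for an effect already at smaller amounts), compound 1 (`COc1ccc(-c2ccccc2C#N)c(OC)c1OC`) gives > 100000 nM as a limit of the assay and not as a number. Among the compounds with values here, compound 2 (`COc1ccc(C2CC=CCC2C#N)c(OC)c1OC`) gives 2290 nM in this assay and supplies the only actual number so far. Compound 3 (`COc1ccc(-c2ccc(OC)c(OC)c2OC)c(C#N)c1`) comes from compound 1 through one change, methoxy in place of hydrogen on an aromatic carbon. Within the data shown here, no measured pair shows what this change does in this assay so the expectation starts from compound 1 alone. Compound 1 stands at the limit of > 100000 nM in this assay, at which 1 of the 2 values shown sits, and this limit is the only anchor. Only a small change is expected, with an estimated step that the limit leaves unreadable from compound 1 to compound 3 and no gain beyond the scatter foreseen. For compound 3 the estimated value is 120000 nM with an expected range from 30000 nM to 400000 nM in this read-out.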

Compound 3, half-maximal effective concentration: > 100000 nM
Compound 3: no number, only a limit; the forecaster's own chance of this, stated with the estimate: 60%; the middle value lies beyond the limit too.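

Compound 1 and compound 3 both rest on a limit of this assay and not on a number, so no step can be read between them: the limit of > 100000 nM in this assay, at which 2 of the 3 values shown sit.

The compounds shown leave open what methoxy in place of hydrogen on an aromatic carbon does in this assay when the starting compound gives an actual number.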